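The compounds below may be only part of what the source reports. "The series", "measured", "known", "first", "only" and "open" are said of these compounds alone.

Compound 1 `CC1(C)[C@H]2CC[C@]1(C)N(Cc1cn(-c3cccc(F)c3)nn1)C(=O)C2` belongs to a small set of analogues built on a shared core that carry a substituted phenyl on an aromatic nitrogen. In a functional assay on SGC-7901 cells (Homo sapiens) for inhibition, read by MTT assay, with a stated time of 24 h (a higher number here means a weaker inhibitor, a lower number a stronger inhibitor), compound 1 gives 530 nM. Compound 2 `CC1(C)[C@H]2CC[C@]1(C)N(Cc1cn(-c3ccccc3Br)nn1)C(=O)C2` gives 500 nM in this assay, and compound 3 `CC1(C)[C@H]2CC[C@]1(C)N(Cc1cn(-c3cccc(Cl)c3)nn1)C(=O)C2` gives 510 nM. Compound 1 sits among them with every step within the scatter: a 1.1-fold lower number from compound 1 to compound 2 (0.03 log units; within the scatter), and a 1.0-fold lower number from compound 1 to compound 3 (0.02 log units; within the scatter). Compound 4 `CC1(C)[C@H]2CC[C@]1(C)N(Cc1cn(-c3ccc(Cl)cc3)nn1)C(=O)C2` has not yet been measured in this assay; it differs from compound 1 in one place: 4-chlorophenyl in place of 3-fluorophenyl on an aromatic nitrogen. The two steps just cited bear on this change, as each alters only the phenyl on the aromatic nitrogen, and both stayed within the scatter, so no step beyond the scatter is expected in this assay. Compound 4 is therefore estimated at 520 nM, in the range 300 nM to 900 nM, an expected step of a 1.0-fold lower number from compound 1 to compound 4 (0.01 log units; within the scatter).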

Compound 4, half-maximal inhibitory concentration: 410 nM
The estimate for compound 4 lay 1.3-fold (0.10 log units) above the measured number; measured number inside the range.
By their numbers in this assay, from the lowest: compounds 4, 2, 3 and 1 (each within the scatter of the next).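

In this assay the 4-chlorophenyl group gives a 1.3-fold lower number from compound 1 to compound 4 (0.11 log units; within the scatter) and a 1.2-fold lower number from compound 3 to compound 4 (0.09 log units; within the scatter) and also a 1.2-fold lower number from compound 2 to compound 4 (0.09 log units; within the scatter) and so adds a further substitution place on the phenyl without a step beyond the scatter. The step from compound 3 changes only where the chloro stands, and even this change stays within the scatter.

Going by these compounds, whether an amine or a carboxylic acid on the phenyl, or a longer chain in its place, would move the number beyond the scatter remains open. Nothing available explains the numbers seen across these four compounds.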